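The source may hold more compounds than are shown below. What is called first, only, known or untested is meant among the compounds shown, and "the series" means these compounds.

Compound 1 `O=C(CCCCC1CCSS1)Nc1cccc2ccccc12`: 0.34%
Compound 2 `Cc1cccc(NC(=O)CCCCC(S)CCS)c1`: 4.92%

In a functional assay on HO8910 cells (Homo sapiens) for inhibition, read by MTT assay, with a stated time of 24 h, tested at 0.1 ug/mL (a lower number here means less inhibition of growth, a higher number more inhibition of growth at the concentration tested), compound 1 gives 0.34% and compound 2 gives 4.92%. These two numbers lie within the usual scatter of each other, so compound 1 cannot be ranked against compound 2.

Compound 3 `O=C(CCCCC(S)CCS)Nc1cccc2ccccc12` is still unmeasured. It keeps the core of compound 1 and changes one group, on a saturated chain carbon, four bonds along the chain from a carbonyl carbon: a group of 5 heavy atoms (3 carbon, 2 sulfur; no ring) in place of a group of 5 heavy atoms (3 carbon, 2 sulfur; one five-membered non-aromatic ring with 2 hetero atoms), on a saturated chain carbon, four bonds along the chain from a carbonyl carbon. The ring is gone, and 1,3-disulfanylpropyl stands in its place.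

Going by the values given here, no measured pair shows this change alone. Compound 2 also carries 1,3-disulfanylpropyl but differs from compound 3 elsewhere. Compound 2 gives 4.92%. This points to little change. Expected is a number 4.7 percentage points higher from compound 1 to compound 3 (within the scatter), a small upward step that stays within the scatter. For compound 3 the estimated value is 5%, with an expected range from 0% to 15%.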

Compound 3, percent growth inhibition at one concentration: 0.76%
Compound 3: the middle estimate sits 4.2 percentage points above what was measured; the measured number falls inside the stated range.
By their numbers in this assay, from the lowest: compounds 1, 3 and 2 (each within the scatter of the next).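

Going by these compounds alone, compound 3 shows for the first time what this change does alone, with the shared core kept. In this assay, replacing the five-membered ring of compound 1 with 1,3-disulfanylpropyl, on a saturated chain carbon, four bonds along the chain from a carbonyl carbon, gives a number 0.4 percentage points higher from compound 1 to compound 3 (within the scatter). The entering group carries hydrogen-bond donors that the ring lacks, yet at this single concentration the swap produces no difference that can be read beyond the scatter. No supporting measurement bears on this result.

All three compounds lie close together at this one concentration, so they leave open whether this position can influence growth inhibition at all. On these data alone, whether a carboxylic acid or an amine on this chain would give a number beyond the scatter remains unknown.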